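A few compounds are considered here, and "the series" means these few. Any claim that something is new, unique, unknown or untested is made for them only; others in the source may bear on it.

Measured compounds:
Compound 1 `CCOc1cc(/C=N/Nc2nc(N)c3ncn([C@@H]4O[C@H](CO)[C@@H](O)[C@H]4O)c3n2)ccc1O` gives 6940 nM in an assay on CHO-K1 cells for displacement of a labelled ligand from adenosine receptor A1 (Homo sapiens), read by scintillation counting, with a stated time of 60 min; a lower number here means a stronger inhibitor, a higher number a weaker inhibitor.
Compound 2 `Nc1nc(N/N=C/c2cccnc2Cl)nc2c1ncn2[C@@H]1O[C@H](CO)[C@@H](O)[C@H]1O` gives 4.6 nM in this assay.

Compound 2 holds the lowest of the two numbers; its nearest neighbour is compound 1, and the step of a 1500-fold lower number from compound 1 to compound 2 (3.18 log units; beyond the scatter) lies well beyond the scatter. Compound 3 `CCCOc1ccc(/C=N/Nc2nc(N)c3ncn([C@@H]4O[C@H](CO)[C@@H](O)[C@H]4O)c3n2)cc1` differs from compound 2 in one place: 4-propoxyphenyl in place of 2-chloropyridin-3-yl on a carbon with a double bond to nitrogen. Going by the values given here, the single measured step that bears on this change is a 1500-fold lower number from compound 1 to compound 2 (3.18 log units; beyond the scatter), in which a substituted phenyl ring was replaced by the chloropyridinyl ring; the new compound reverses that direction, again placing an alkoxy-substituted phenyl on the carbon with a double bond to nitrogen. The change therefore is expected to raise the number by a large step, a 330-fold higher number from compound 2 to compound 3 (2.51 log units; beyond the scatter), though the propoxyphenyl ring is not the same as that of compound 1, so the size is uncertain. Compound 3 is estimated at 1500 nM, with a range from 250 nM to 8000 nM.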

Compound 3, inhibition constant: > 10000 nM
Compound 3 was reported as a limit (the forecaster's own chance of this, stated with the estimate: 10%); at least 6.6-fold (0.82 log units) between middle value and limit.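

Compound 3 is reported only as a limit of the assay: the limit of > 10000 nM in this assay, at which 1 of the 3 values shown sits.

With an at least 2100-fold higher number from compound 2 to compound 3 (3.33 log units; beyond the scatter), a second phenyl ring carrying an alkoxy group on the carbon with a double bond to nitrogen also falls far from the 2-chloropyridin-3-yl group in this assay, so neither phenyl compound shown shares the low number of compound 2. The other new step is an at least 1.4-fold higher number from compound 1 to compound 3 (0.15 log units; that floor lies within the scatter), so 4-propoxyphenyl and 3-ethoxy-4-hydroxyphenyl cannot be ranked against each other.

The compounds shown leave open whether the chlorine or the ring nitrogen of the 2-chloropyridin-3-yl group goes with the low number, a question that a 2-chlorophenyl or a pyridin-3-yl group would address. As far as these compounds go, how far compound 3 lies beyond its limit also stays open.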